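A few compounds are considered here, and "the series" means these few. Any claim that something is new, unique, unknown or untested is made for them only; others in the source may bear on it.

Measured so far:
Compound 1 `Cc1ccc2nc(N3CCCc4ccc(F)cc4C3)cc(NCC3(N)COC3)c2c1` — > 100000 nM
Compound 2 `NCCCNc1cc(N2CCc3ccccc3C2)nc2ccccc12` — 8400 nM

Compound 1 in an ADME assay on HEp-2 cells (Homo sapiens) for cytotoxicity, read by CCK-8 assay, with a stated time of 5 days (a lower number here means that less compound is tolerated, a higher number that more compound is tolerated), gives > 100000 nM, which is a limit of the assay and not a number. Compound 2 in this assay gives 8400 nM. Compound 2 thus holds the only number shown in this assay. The other entry is the limit of > 100000 nM in this assay, at which 1 of the 2 values shown sits. Compound 1 and compound 2 differ in several places at once, so no single step between them can be read, and nothing is said here about why they differ.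

Compound 3 `NC(=O)NCCNc1cc(N2CCc3ccccc3C2)nc2ccccc12` is not yet measured. It differs from compound 2 by ureido in place of aminomethyl on a saturated chain carbon, two bonds along the chain from a nitrogen on an aromatic ring; cut one bond further out, the same difference reads (3-aminopropyl)amino to (2-ureidoethyl)amino.

Among the measured compounds shown here, no step between measured compounds is available, so the size of the change can only be expected, not read off. In this assay the expectation is a modest rise, toward more compound tolerated, somewhat beyond the usual scatter but not large. Compound 3 is estimated at 20000 nM, with a range from 7000 nM to 60000 nM. The expected step is a 2.4-fold higher number from compound 2 to compound 3 (0.38 log units; beyond the scatter).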

Compound 3, half-maximal cytotoxic concentration: 80000 nM
Beside the measured number, compound 3's estimate is 4.0-fold (0.60 log units) below it, and the stated range ends below it.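

In this assay, ureido in place of aminomethyl on a saturated chain carbon, two bonds along the chain from a nitrogen on an aromatic ring, gives a 9.5-fold higher number from compound 2 to compound 3 (0.98 log units; beyond the scatter). This position therefore matters in this assay: with the rest of the structure held constant, a change in this chain alone moves the number beyond the scatter, toward more compound tolerated, something that compound 1 and compound 2 could not show, as they differ in several places at once. Compound 1 remains the only entry held at a limit of the assay, which is not a number: the limit of > 100000 nM in this assay, at which 1 of the 3 values shown sits.

Going by these compounds, the step read as (3-aminopropyl)amino to (2-ureidoethyl)amino changes the end group and the chain together, so the share of each in the rise stays open. A 2-aminoethyl or 3-ureidopropyl chain on the same core would separate the two, and a carboxylic acid at the chain end would show whether the number also moves with an end group other than the amine or the ureido.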